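Replacing the acyl group of compound 3 with propanoyl

The source may hold more compounds than are shown below. What is called first, only, known or untested is meant among the compounds shown, and "the series" means these compounds.

Among the measured compounds shown here, compound 3 `Cc1ccc(C(=O)N2N=C(c3cc4ccccc4oc3=O)CC2c2ccccc2)cc1` stands highest of the two numbers so far in a functional assay on MGC-803 cells (Homo sapiens) for cytotoxicity, read by MTT assay, with a stated time of 48 h; on this read-out higher numbers stand for weaker inhibition and lower numbers for stronger inhibition. Its nearest neighbour is compound 2 `O=C(c1ccccc1)N1N=C(c2cc3ccccc3oc2=O)CC1c1ccccc1`, which gives 12700 nM in this assay, while compound 3 gives 31300 nM. For the measured compounds named here, the only change measured between them is a 2.5-fold higher number from compound 2 to compound 3 (0.39 log units; beyond the scatter). Compound 1 `CC1=NN(S(=O)(=O)c2ccc([N+](=O)[O-])cc2)C(c2cc(Cl)ccc2O)C1` was reported in this assay as "not active" (no number reported), without a number, and so cannot be placed on the scale.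

Compound 4 `CCC(=O)N1N=C(c2cc3ccccc3oc2=O)CC1c1ccccc1` differs from compound 3 by ethyl in place of 4-methylphenyl on a carbonyl carbon. Going by the values given here, no measured step covers an exchange of this kind; the single step from compound 2 to compound 3 touches the same acyl group but alters it in a different way and was modest in size. With nothing pointing strongly in either direction, the change from compound 3 to compound 4 is expected to stay modest, a 1.6-fold lower number from compound 3 to compound 4 (0.19 log units; within the scatter), with the direction uncertain. Compound 4 is therefore estimated at 20000 nM in this assay, within a range of 6000 nM to 70000 nM.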

Compound 4, half-maximal inhibitory concentration: 5300 nM
Estimate against measurement, compound 4: 3.8-fold (0.58 log units) above; the measured number lies below the stated range.
By their numbers in this assay, from the lowest: compound 4; then compound 2; then compound 3.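

Shortening the acyl group, and not only decorating its aromatic ring, shifts the read-out in this assay: ethyl in place of 4-methylphenyl on the carbonyl carbon gives a 5.9-fold lower number from compound 3 to compound 4 (0.77 log units; beyond the scatter) and the earlier compounds had shown only a methyl added to that ring. Ethyl in place of phenyl at the same carbon gives a 2.4-fold lower number from compound 2 to compound 4 (0.38 log units; beyond the scatter) so among these three compounds, both aromatic acyl groups give higher numbers than propanoyl, and an aromatic ring on this carbonyl carbon is not required for the stronger inhibition seen here. No measurement available here accounts for either step.

The compounds shown leave open whether acetyl, butanoyl or a longer chain on this carbonyl carbon would fall on the same side as propanoyl. They also leave open how an acyl group carrying an amine or a carboxylic acid would read.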